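The source may report more compounds than this note shows. Statements on the series, on what has been measured and on what is new or still open speak of the compounds shown alone.

Compound 3 `C=C1CC[C@@H]2[C@](C)(CNCc3ccc(Cl)cc3)[C@H](O)CC[C@@]2(C)[C@@H]1/C=C/C1=CCOC1=O` carries a 4-chlorobenzyl group on the shared core. In a functional assay on BMMC cells (Mus musculus, strain C57BL/6) for inhibition, with stated times of 5 days and 48 h (a lower number here means a stronger inhibitor, a higher number a weaker inhibitor), compound 3 gives 420 nM, the second highest of three numbers. Compound 1 `C=C1CC[C@@H]2[C@](C)(CNCc3ccccc3)[C@H](O)CC[C@@]2(C)[C@@H]1/C=C/C1=CCOC1=O`, with an unsubstituted benzyl, gives 960 nM, and compound 2 `C=C1CC[C@@H]2[C@](C)(CNCc3ccc(F)cc3)[C@H](O)CC[C@@]2(C)[C@@H]1/C=C/C1=CCOC1=O` gives 350 nM. Both a 2.7-fold lower number from compound 1 to compound 2 (0.44 log units; beyond the scatter) and a 2.3-fold lower number from compound 1 to compound 3 (0.36 log units; beyond the scatter) were modest, while a 1.2-fold higher number from compound 2 to compound 3 (0.08 log units; within the scatter) stayed within the scatter. Compound 4 `C=C1CC[C@@H]2[C@](C)(CNCc3ccc([N+](=O)[O-])cc3)[C@H](O)CC[C@@]2(C)[C@@H]1/C=C/C1=CCOC1=O` differs from compound 3 in one place: nitro in place of chloro on an aromatic carbon. For the measured compounds named here, no measured step exchanges chloro for another group at this position, so the two substituted compounds offer the only guide. Compound 4 is therefore expected to show a step of a 1.1-fold lower number from compound 3 to compound 4 (0.02 log units; within the scatter), within the scatter. Compound 4 is estimated at 400 nM, with a range from 200 nM to 800 nM.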

Compound 4, half-maximal inhibitory concentration: 1340 nM
The estimate for compound 4 lay 3.4-fold (0.53 log units) below the measured number, outside the stated range (above it).
By their numbers in this assay, from the lowest: compounds 2 and 3 (each within the scatter of the next); then compounds 1 and 4 (each within the scatter of the next).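

In this assay, the gain seen with fluoro and chloro at this aromatic position does not extend to every replacement of hydrogen: nitro gives a 3.2-fold higher number from compound 3 to compound 4 (0.50 log units; beyond the scatter) and a 3.8-fold higher number from compound 2 to compound 4 (0.58 log units; beyond the scatter), while a 1.4-fold higher number from compound 1 to compound 4 (0.14 log units; within the scatter) stays within the scatter. The position therefore distinguishes between substituents, and the 4-nitrobenzyl group shows no measurable gain over the unsubstituted benzyl. Nothing measured here accounts for the difference between nitro and the two halogens. Going by these compounds, whether a methoxy group or an amine here would match the halogens or nitro remains open.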